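A few compounds are considered here, and "the series" means these few. Any claim that something is new, unique, unknown or untested is made for them only; others in the source may bear on it.

Series notes. The shared core carries a substituted phenyl on an aromatic nitrogen, and the three measured compounds differ only in that phenyl. Compound 1 `CNC(=O)c1cc(Oc2ccc(NC(=O)c3cc4cccnc4n(-c4ccc(Cl)cc4)c3=O)cc2)ccn1` in a functional assay on A549 cells (Homo sapiens) for antiproliferative activity, read by MTT assay, with a stated time of 72 h (a higher number here means a weaker inhibitor, a lower number a stronger inhibitor), gives 370 nM. Compound 2 `CNC(=O)c1cc(Oc2ccc(NC(=O)c3cc4cccnc4n(-c4ccc(Br)cc4)c3=O)cc2)ccn1` gives 1050 nM in this assay. Compound 3 `CNC(=O)c1cc(Oc2ccc(NC(=O)c3cc4cccnc4n(-c4ccc(OC)cc4)c3=O)cc2)ccn1` gives 3110 nM in this assay. Among these three numbers compound 2 sits second highest: a 2.8-fold higher number from compound 1 to compound 2 (0.45 log units; beyond the scatter), while a 3.0-fold higher number from compound 2 to compound 3 (0.47 log units; beyond the scatter), and across the whole spread an 8.4-fold higher number from compound 1 to compound 3 (0.92 log units; beyond the scatter).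

Compound 4 `CNC(=O)c1cc(Oc2ccc(NC(=O)c3cc4cccnc4n(-c4ccc(F)c(Cl)c4)c3=O)cc2)ccn1` is not yet measured. Its change from compound 2 is 3-chloro-4-fluorophenyl in place of 4-bromophenyl on an aromatic nitrogen. The measured step that bears on it is a 2.8-fold higher number from compound 1 to compound 2 (0.45 log units; beyond the scatter); read in reverse, chloro in place of bromo on that phenyl went with a lower number in this assay. Within the data shown here, compound 4 brings the chloro back, though within a 3-chloro-4-fluorophenyl group that no measured compound carries, so the added fluorine has no precedent here and the chloro-versus-bromo comparison is the only guide. For compound 4 the expected step is therefore a modest move to a lower number, a 2.3-fold lower number from compound 2 to compound 4 (0.37 log units; beyond the scatter), rather than none beyond the scatter. Compound 4 is estimated at 450 nM, with a range from 150 nM to 1300 nM.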

Compound 4, half-maximal inhibitory concentration: 1560 nM
Beside the measured number, compound 4's estimate is 3.5-fold (0.54 log units) below it; measured number above the stated range.
By their numbers in this assay, from the lowest: compound 1; then compounds 2, 4 and 3 (each within the scatter of the next, the first and the last beyond it).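

In this assay the exchange of 4-bromophenyl for 3-chloro-4-fluorophenyl on the aromatic nitrogen gives a 1.5-fold higher number from compound 2 to compound 4 (0.17 log units; within the scatter) and so does not separate these two groups, and the comparison with the 4-methoxyphenyl group, at a 2.0-fold lower number from compound 3 to compound 4 (0.30 log units; within the scatter) also stays unresolved. Only the 4-chlorophenyl group stands apart, with a 4.2-fold higher number from compound 1 to compound 4 (0.62 log units; beyond the scatter) and this shows that a chloro on this phenyl does not by itself go with the low number of compound 1, since the two chlorine-bearing groups differ beyond the scatter. Nothing available explains these numbers.

Still open, as far as these compounds go, is which part of the change from 4-chlorophenyl to 3-chloro-4-fluorophenyl goes with the higher number, the added fluorine or the different chloro position; a 3-chlorophenyl or a 4-fluorophenyl group on the same nitrogen would separate the two. Also open, from the compounds shown here alone, is how an amine or a carboxylic acid on this phenyl would read in this assay against the halogens and the methoxy group.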